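The compounds below may be only part of what the source reports. "The series", "measured", "known", "first", "only" and "open" are said of these compounds alone.

Measured compounds:
compound 1, `CCC(Sc1nc2c(cnn2C)c(=O)n1-c1ccccc1)c1ccccc1`, 150 nM
compound 2, `Cn1ncc2c(=O)n(-c3ccccc3)c(OCc3cccc(F)c3)nc21`, 775 nM
compound 3, `O=c1c2cncn2nc(SCc2cccc(F)c2)n1-c1ccccc1`, 2200 nM

Of the compounds shown here, three have been measured in an assay on isolated protein for inhibition of aldehyde dehydrogenase 1A1 (Homo sapiens) (a lower number here means a stronger inhibitor, a higher number a weaker inhibitor), and compound 1 gives the lowest number of the three; compound 2 stands at a higher number, beyond the scatter, and compound 3 at a higher number still, also beyond the scatter. No two of these compounds differ in only one place, so none of the gaps between them can be tied to a single structural change.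

The next compound is compound 4, `CC(Sc1nc2c(cnn2C)c(=O)n1-c1ccccc1)c1cccnc1`, which has not yet been measured in this assay. It differs from compound 1 in one place: 1-(pyridin-3-yl)ethyl in place of 1-phenylpropyl on a sulfur. Going by the values given here, no measured pair shows this change, so the size of the step from compound 1 to compound 4 cannot be read from the data. Taking compound 1 as the starting point with its 150 nM, a modest step toward a higher number is expected, one that may or may not exceed the scatter; the step from compound 1 to compound 4 is estimated at a 2.0-fold higher number from compound 1 to compound 4 (0.30 log units; within the scatter). For compound 4 in this assay the expected value is 300 nM, with a range from 100 nM to 1000 nM.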

Compound 4, half-maximal inhibitory concentration: 139 nM
Estimate against measurement, compound 4: 2.2-fold (0.33 log units) above; the measured number falls inside the stated range.
By their numbers in this assay, from the lowest: compounds 4 and 1 (each within the scatter of the next); then compound 2; then compound 3.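

In this assay, going by these compounds alone, the step on the sulfur reads a 1.1-fold lower number from compound 1 to compound 4 (0.03 log units; within the scatter), the first single-place comparison. This position therefore accepts 1-(pyridin-3-yl)ethyl as well as 1-phenylpropyl with no readable difference, although the replacement alters both the aromatic ring, which now holds a nitrogen, and the chain on the carbon attached to the sulfur, so the all-carbon aromatic ring of compound 1 is not required for a value at this level, at least when the chain changes with it. No available measurement explains why these two groups give indistinguishable values.

Because the ring and the chain change together here, the contribution of each stays unresolved, and 1-phenylethyl or 1-(pyridin-3-yl)propyl on the same sulfur would be needed to separate them. Going by these compounds, how far this position tolerates other groups also remains open, including a pyridin-2-yl or pyridin-4-yl ring, a longer chain, or an amine or a carboxylic acid on the ring.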